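This account rests on a few compounds, and the source may have more. Where it says the series, first, only, none or still open, it means among the compounds named here.

Values in an ADME assay on L02 cells (Homo sapiens) for inhibition, read by CCK-8 assay, with a stated time of 48 h (on this read-out lower numbers stand for stronger inhibition of growth and higher numbers for weaker inhibition of growth), follow
Compound 1 `Cc1ccccc1Nc1nc(Nc2ccccn2)ncc1Cl` gives 6150 nM
Compound 2 `Cc1ccccc1Nc1nc(Nc2ccc(N3CCN(C)CC3)cn2)ncc1Cl` gives 5980 nM
Compound 3 `CCN1CCN(c2ccc(Nc3ncc(Cl)c(Nc4ccccc4C)n3)nc2)CC1` gives > 100000 nM as a limit of the assay, not a number

Compound 3 has no number, and its position is given only by the limit of > 100000 nM in this assay, at which 1 of the 3 values shown sits. Compound 4 `Cc1ccccc1Nc1nc(Nc2ccc(N3CCNCC3)cn2)ncc1Cl` differs from it by hydrogen in place of ethyl on an amine nitrogen in a ring with hydrogen in place of ethyl on an amine nitrogen in a ring, so that 4-ethylpiperazin-1-yl becomes piperazin-1-yl.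

For the measured compounds named here, three measured steps bear on this change. Placing 4-methylpiperazin-1-yl on the core of compound 1 gives a 1.0-fold lower number from compound 1 to compound 2 (0.01 log units; within the scatter) and no shift beyond the scatter. Placing 4-ethylpiperazin-1-yl there gives an at least 16-fold higher number from compound 1 to compound 3 (1.21 log units; beyond the scatter) instead. The extra methyl alone gives an at least 16-fold higher number from compound 2 to compound 3 (1.22 log units; beyond the scatter) and is equally large. Among these three compounds, only compound 3 stands apart. Compound 4 is therefore expected to return close to compound 1 and compound 2, a large step down in this assay whose exact size is uncertain since it starts from a limit.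

The estimated change is an at least 15-fold lower number from compound 3 to compound 4 (1.18 log units; beyond the scatter) in this direction. Compound 4 is expected at 6500 nM with an estimated range from 2000 nM to 40000 nM.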

Compound 4, concentration for 50% growth inhibition: 1850 nM
Estimate against measurement, compound 4: 3.5-fold (0.55 log units) above, and the stated range ends above it.
By their numbers in this assay, from the lowest: compound 4; then compounds 2 and 1 (each within the scatter of the next). At a limit, above all of these: compound 3.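

In this assay, hydrogen in place of ethyl on the amine nitrogen in the ring gives an at least 54-fold lower number from compound 3 to compound 4 (1.73 log units; beyond the scatter). For the compounds shown here, that step starts from a limit and not a number, the only position known for compound 3: the limit of > 100000 nM in this assay, at which 1 of the 4 values shown sits. What is new is that piperazin-1-yl does not merely return to the level of the earlier pair: hydrogen in place of methyl gives a 3.2-fold lower number from compound 2 to compound 4 (0.51 log units; beyond the scatter), and piperazin-1-yl on the core of compound 1 gives a 3.3-fold lower number from compound 1 to compound 4 (0.52 log units; beyond the scatter), whereas 4-methylpiperazin-1-yl there caused no shift beyond the scatter.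

The compounds shown leave open whether the jump belongs to ethyl alone, or whether a longer chain, a hydroxyethyl or an acetyl on the same nitrogen would behave alike. Going by these compounds, how far compound 3 truly lies from the others also remains unknown.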